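A few compounds are considered here, and "the series" means these few. Any claim that something is new, unique, unknown or untested is made for them only; others in the source may bear on it.

Series notes. In a physicochemical assay for solubility, at pH 1.1 (on this read-out higher numbers stand for higher solubility and lower numbers for lower solubility), compound 1 (`CCCN(Cc1ccc(OCCn2c(=O)ccn(C)c2=O)c(C)c1)C(CC(=O)O)c1ccc(Cl)cc1`) reads 3000000 nM and compound 2 (`Cc1cc(CN(C2CCC2)C(CC(=O)O)c2ccc(Cl)cc2)ccc1OCCn1c(=O)ccn(C)c1=O`) reads 3000000 nM in the same test, while compound 3 (`CCCN(Cc1ccc(OCCn2c(=O)ccn(C)c2=O)c(OC)c1)C(CC(=O)O)c1ccc(Cl)cc1`) reads 3000000 nM and stands level with both. Compound 4 (`COc1cc(CN(C2CCC2)C(CC(=O)O)c2ccc(Cl)cc2)ccc1OCCn1c(=O)ccn(C)c1=O`) differs from compound 3 by one exchange, cyclobutyl in place of propyl on an amine nitrogen on the shared core. The same exchange gave no change at the digits printed from compound 1 to compound 2 (within the scatter) in this assay and methoxy in place of methyl gave no change at the digits printed from compound 1 to compound 3 (within the scatter) on that core. Neither measured step lies beyond the scatter, so the expected outcome is no change at the digits printed from compound 3 to compound 4 (within the scatter) with no direction favoured. For compound 4 the estimated value is 3000000 nM within an expected range from 2000000 nM to 4000000 nM on this read-out.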

Compound 4, solubility: 3000000 nM
Compound 4: the middle estimate sits on the measured number at the digits printed, within the range that was stated.
By their numbers in this assay, from the lowest: compounds 1, 2, 3 and 4 (each within the scatter of the next).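

With methoxy on the aromatic carbon, cyclobutyl in place of propyl on an amine nitrogen gives no change at the digits printed from compound 3 to compound 4 (within the scatter) in this assay, so this exchange now reads the same alongside methyl and methoxy. With cyclobutyl on the nitrogen, methoxy in place of methyl gives no change at the digits printed from compound 2 to compound 4 (within the scatter), which extends that exchange beyond the propyl compounds and leaves no step beyond the scatter among compounds 1 to 4. Nothing available offers an explanation for these readings.

Going by these compounds, whether a longer chain or a piperidine ring on the amine nitrogen would read the same remains open. So does the outcome for fluorine or an amine on the aromatic carbon.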